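The compounds below may be only part of what the source reports. "The series", "measured", "known", "first", "only" and "open" are said of these compounds alone.

Measured so far:
- compound 1 `CCC[C@@H]1NC[C@@H](C)Oc2ccccc2CCCNC(=O)[C@@H](Cc2ccc(F)cc2)NC(=O)[C@@H](C)N(C)C1=O`: 1.7 L/kg
- compound 2 `C[C@@H]1CN[C@@H](C2CC2)C(=O)N(C)[C@H](C)C(=O)N[C@H](Cc2ccccc2)C(=O)NCCCc2ccccc2O1`: 1.3 L/kg
- compound 3 `C[C@@H]1C(=O)N[C@H](Cc2ccc(F)cc2)C(=O)NCCCc2cccc3c2O[C@H](CC3)CN[C@@H](C2CC2)C(=O)N1C`: 1.1 L/kg

In an in vivo ADME assay on the whole organism (strain Sprague-Dawley) for pharmacokinetics, with Rattus norvegicus as the target (a higher number here means that more of the compound sits outside the plasma, a lower number that more of the compound stays in the plasma), compound 1 gives 1.7 L/kg. This value lies within the usual scatter of both other compounds, so the data set no order among the three.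

Compound 4 `CC[C@H](C)[C@@H]1NC[C@@H](C)Oc2ccccc2CCCNC(=O)[C@@H](Cc2ccc(F)cc2)NC(=O)[C@@H](C)N(C)C1=O` keeps the core of compound 1 and carries one change: methyl in place of hydrogen on a saturated chain carbon bound to a saturated chain carbon and a saturated ring carbon. This is methyl in place of hydrogen on a saturated chain carbon bound to a saturated chain carbon and a saturated ring carbon, or propyl to sec-butyl when cut one bond further out.

For the measured compounds named here, no pair of measured compounds differs in a single place, so the series offers no direct precedent for this step. Compound 2 at 1.3 L/kg and compound 3 at 1.1 L/kg differ from compound 1 in more than one place, yet both remain within the scatter of it. No step beyond the scatter is therefore expected, and no direction can be argued with confidence. The expected result is a 1.1-fold higher number from compound 1 to compound 4 (0.02 log units; within the scatter), a step within the scatter. For compound 4 the estimate is 1.8 L/kg, with an expected range of 1 L/kg to 3 L/kg.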

Compound 4, volume of distribution at steady state: 2.5 L/kg
For compound 4 the middle estimate is 1.4-fold (0.14 log units) below the measured one; the measured number falls inside the stated range.
By their numbers in this assay, from the lowest: compounds 3, 2, 1 and 4 (each within the scatter of the next, the first and the last beyond it).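

For the compounds shown here, the step of a 1.5-fold higher number from compound 1 to compound 4 (0.17 log units; within the scatter) in this assay is the first single-place comparison, and it comes from methyl in place of hydrogen on a saturated chain carbon bound to a saturated chain carbon and a saturated ring carbon. It lies within the scatter, so propyl to sec-butyl at this position on the core of compound 1 gives no resolved shift in this read-out. No available measurement bears on what underlies this result.

The compounds shown leave open whether a longer chain such as hexyl, or an amine on this same carbon, would give a step beyond the scatter. On these data alone, it also remains open whether the other stereoisomer of the sec-butyl group would read the same as compound 4.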